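One Small Change, Tried Twice

The source may report more compounds than this note shows. Statements on the series, on what has been measured and on what is new or still open speak of the compounds shown alone.

Three compounds share a core and were measured in an ADME assay on Vero cells (Chlorocebus sabaeus) for cytotoxicity, read by MTT assay, with a stated time of 72 h; on this read-out higher numbers stand for lower toxicity in this test and lower numbers for higher toxicity in this test. Compound 1 `CCO/N=C1\C(=O)N(CCCCOc2ccc3oc(-c4ccc(OC)cc4)c(C(=O)OCC)c3c2)c2ccc(F)cc21` gives 32 ug/mL, compound 2 `CCOC(=O)c1c(-c2ccc(OC)cc2)oc2ccc(OCCCCN3C(=O)/C(=N\OC)c4cc(F)ccc43)cc12` gives 32 ug/mL, and compound 3 `CCOC(=O)c1c(-c2ccc(OC)cc2)oc2ccc(OCCCN3C(=O)/C(=N\OC)c4cc(OC)ccc43)cc12` gives 128 ug/mL. Compound 2 and compound 1 differ in one place: methyl in place of hydrogen on a saturated chain carbon bound to an oxygen on an unsaturated carbon. This gave no change at the digits printed from compound 2 to compound 1 (within the scatter). Compound 3 differs from compound 2 in more than one place, and the difference between the two cores is not broken down here; what is known is that compound 3 shows the highest of the three numbers, with both compound 1 and compound 2 beyond the scatter below it.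

Compound 4 `CCO/N=C1\C(=O)N(CCCOc2ccc3oc(-c4ccc(OC)cc4)c(C(=O)OCC)c3c2)c2ccc(OC)cc21` has not yet been measured in this assay. It differs from compound 3 by methyl in place of hydrogen on a saturated chain carbon bound to an oxygen on an unsaturated carbon, the same change as that from compound 2 to compound 1, at the same place. Because that earlier change gave no change at the digits printed from compound 2 to compound 1 (within the scatter), a similarly flat step is expected here, no change at the digits printed from compound 3 to compound 4 (within the scatter). Compound 4 is therefore expected to give about 128 ug/mL in this assay, most likely between 64 ug/mL and 256 ug/mL.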

Compound 4, half-maximal cytotoxic concentration: 32 ug/mL
For compound 4 the middle estimate is 4.0-fold (0.60 log units) above the measured one; measured number below the stated range.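

In this assay the change from methoxy to ethoxy gave a 4.0-fold lower number from compound 3 to compound 4 (0.60 log units; beyond the scatter) on this core, which on this read-out means higher toxicity in this test. Set beside the earlier step, the same change did not carry over unchanged from one core to the other: the same change on two cores in this assay, no change at the digits printed (within the scatter) from compound 2 to compound 1 and a 4.0-fold lower number (0.60 log units; beyond the scatter) from compound 3 to compound 4, 4.0-fold (0.60 log units) apart, beyond the scatter of two such steps

This shows that, in these two pairs, the outcome of the change depends on the core that carries it, so a flat step on one core is no safe guide to the next. It does not show which of the differences between the core of compound 2 and the core of compound 3 matters, and two pairs cannot set a rule for the whole series.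

The compounds shown leave open how a longer chain such as propoxy, or a group bearing an amine or a carboxylic acid, would read at this place on either core. Also open, from the compounds shown here alone, is how the change would behave on two cores that differ in one place only.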